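A few compounds are considered here, and "the series" means these few. Any claim that something is new, unique, unknown or untested is made for them only; others in the source may bear on it.

Notes on the series in a physicochemical assay for solubility, using the shake flask method, in phosphate buffer, measured as kinetic solubility, with a stated time of 20 h, at pH 6.5; a higher number here means a more soluble compound, a lower number a less soluble compound.

Compound 1 has the structure `FC(F)(F)c1cccc(-c2nc3cnc(Nc4ncccn4)cc3[nH]2)c1`. In this assay compound 1 gives < 5000 nM, which is a limit of the assay and not a number. Compound 2, `Fc1ccc(-c2nc3cnc(Nc4ccc(C(F)(F)F)cn4)cc3[nH]2)cc1F`, gives < 5000 nM in this assay, again a limit. Compound 3, `Fc1ccnc(Nc2cc3[nH]c(-c4ccc(F)c(F)c4)nc3cn2)c1`, gives < 5000 nM, also a limit. Compound 1 therefore stands at the limit of < 5000 nM in this assay, at which 3 of the 3 values shown sit, and no measured value in the set rises above that limit, so nothing here separates the three compounds from one another.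

Compound 4, `O=C(O)c1ccc(Nc2cc3[nH]c(-c4cccc(C(F)(F)F)c4)nc3cn2)nc1`, is not yet measured. It differs from compound 1 in one place: 5-carboxypyridin-2-yl in place of pyrimidin-2-yl on a nitrogen on an aromatic ring. Among the measured compounds shown here, no step between measured compounds is available to size this change, so the expectation rests on the structural change alone. The step from compound 1 to compound 4 in this assay is expected to be upward, as an at least 4.0-fold higher number from compound 1 to compound 4 (0.60 log units; beyond the scatter), beyond the scatter, with a real chance that the assay again returns only a limit. Compound 4 is estimated at 20000 nM in this assay, within a range from 3000 nM to 150000 nM.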

Compound 4, solubility: 6000 nM
Compound 4: middle estimate off by 3.3-fold (0.52 log units), on the high side; the measured number falls inside the stated range.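

In this assay compound 1 gives < 5000 nM, which is a limit of the assay and not a number. With 5-carboxypyridin-2-yl in place of pyrimidin-2-yl on a nitrogen on an aromatic ring, the step is an at least 1.2-fold higher number from compound 1 to compound 4 (0.07 log units; that floor lies within the scatter), so only a floor is known and this change cannot yet be told from the scatter. Compound 4 is the only compound in the set to give a number, while the others remain at the limit: the limit of < 5000 nM in this assay, at which 3 of the 4 values shown sit.

The compounds shown leave open how much of the step belongs to the carboxy group and how much to the change of ring. As far as these compounds go, it also remains open whether an amine or a primary amide carried on the same ring would give a number rather than a limit.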